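Swapping a ring methyl for fluorine on compound 2

This account rests on a few compounds, and the source may have more. Where it says the series, first, only, none or still open, it means among the compounds named here.

Compound 1, `Cc1ccc2nc([C@H](CC3CCNCC3)N3C(=O)CN(c4ccc(Oc5ccccc5)cc4)C3=O)n(C)c2c1`, gives 4510 nM in an assay on cells for antagonist activity at Bile acid receptor (Homo sapiens), read by a luciferase reporter, with a stated time of 24 h; a lower number here means a stronger inhibitor, a higher number a weaker inhibitor.
Compound 2, `CC(=O)N1CCC(C[C@@H](c2nc3ccc(C)cc3n2C)N2C(=O)CN(c3ccc(Oc4ccccc4)cc3)C2=O)CC1`, gives 0.2 nM.
Compound 3, `Cc1ccc2nc([C@H](CC3CCN(C(=O)C(C)C)CC3)N3C(=O)CN(c4ccc(Oc5ccccc5)cc4)C3=O)n(C)c2c1`, gives < 0.001 nM, which is a limit of this assay rather than a number.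

Compound 2 holds the lowest of the two numbers shown; its nearest neighbour is compound 1, which sits a 23000-fold lower number from compound 1 to compound 2 (4.35 log units; beyond the scatter). Compound 3 reaches (the limit of < 0.001 nM in this assay, at which 1 of the 3 values shown sits). Compound 4, `CC(=O)N1CCC(C[C@@H](c2nc3cc(F)ccc3n2C)N2C(=O)CN(c3ccc(Oc4ccccc4)cc3)C2=O)CC1`, differs from compound 2 in one place: 5-fluoro-1-methyl-1H-benzimidazol-2-yl in place of 1,6-dimethyl-1H-benzimidazol-2-yl on a saturated chain carbon bound to an amide-type nitrogen in a ring and a saturated chain carbon. All three measured steps change the substituent on an amine nitrogen in a ring (an at least 4500000-fold lower number from compound 1 to compound 3 (6.65 log units; beyond the scatter), an at least 200-fold lower number from compound 2 to compound 3 (2.30 log units; beyond the scatter)), so none of them touches the part altered in compound 4. Among the compounds with values here, with no measured step bearing on this change, no step beyond the scatter is expected from compound 2 to compound 4; the estimated step is a 1.5-fold higher number from compound 2 to compound 4 (0.18 log units; within the scatter). Compound 4 is therefore expected to give about 0.3 nM in this assay, with a range from 0.05 nM to 3 nM.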

Compound 4, half-maximal inhibitory concentration: 1 nM
The estimate for compound 4 lay 3.3-fold (0.52 log units) below the measured number; the measured number falls inside the stated range.
By their numbers in this assay, from the lowest: compound 2; then compound 4; then compound 1. At a limit, below all of these: compound 3.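

Compound 4 is the first compound shown that changes the benzimidazole group rather than the substituent on the amine nitrogen in a ring, and in this assay this change still registers: a 5.0-fold higher number from compound 2 to compound 4 (0.70 log units; beyond the scatter), a modest step beyond the scatter. The change is far smaller than a 23000-fold lower number from compound 1 to compound 2 (4.35 log units; beyond the scatter), and it combines two edits, since the name of the entering group, 5-fluoro-1-methyl-1H-benzimidazol-2-yl, shows both the loss of the 6-methyl group and the gain of a 5-fluoro group, which this single step cannot separate. Nothing measured here accounts for the step.

The compounds shown leave open how a 6-fluoro, 5-methyl or 6-chloro group would read on the same benzimidazole. Also open, on these data alone, is whether the swap would carry over to compound 3, whose < 0.001 nM is a limit of the assay.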